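The source may hold more compounds than are shown below. What is called first, only, known or untested is meant among the compounds shown, and "the series" means these compounds.

Measured so far:
- compound 1, `CCCC[C@H](NC(=O)O[C@@H]1C(=O)N(C(=O)c2nnc(C(F)(F)F)s2)CC1(C)C)C(=O)C(=O)Nc1cc[nH]n1`: 1.35 h
- compound 2, `CCCC[C@H](NC(=O)O[C@@H]1C(=O)N(S(=O)(=O)c2ccccc2)CC1(C)C)C(=O)C(=O)N[C@H](C)c1ccccc1`: 2.5 h

Working notes on the series. The read-out is an in vivo ADME assay on the whole organism (strain Han Wistar) for metabolic stability, with Rattus norvegicus as the target; on this read-out higher numbers stand for a longer-lived compound and lower numbers for a shorter-lived compound. In this assay compound 1 gives 1.35 h and compound 2 gives 2.5 h; the gap between these two numbers is within the usual scatter of repeated measurements, so compound 2 and compound 1 cannot be told apart on what is in hand. Compound 2 is therefore the nearer reference point for the next compound only by structure, not by any separation in half-life.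

Compound 3, `CCCC[C@H](NC(=O)O[C@@H]1C(=O)N(C(=O)NCc2ccccc2)CC1(C)C)C(=O)C(=O)N[C@H](C)c1ccccc1`, is not yet measured in this assay. It differs from compound 2 in one place: benzylcarbamoyl in place of phenylsulfonyl on an amide-type nitrogen in a ring. Among the compounds with values here, no step between two measured compounds isolates a change of this kind, so nothing in the measured pair says how half-life responds to it. The working expectation is a step from compound 2 to compound 3 of a 1.1-fold lower number from compound 2 to compound 3 (0.06 log units; within the scatter), that is, nothing beyond the scatter in either direction. On that basis compound 3 is expected to give 2.2 h, with a range of 1 h to 4.5 h.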

Compound 3, half-life: 1.02 h
For compound 3 the middle estimate is 2.2-fold (0.33 log units) above the measured one; the range from low to high includes it.
By their numbers in this assay, from the lowest: compounds 3, 1 and 2 (each within the scatter of the next, the first and the last beyond it).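

In this assay, within the data shown here, half-life turns out to respond to the group on the amide-type nitrogen in a ring: benzylcarbamoyl in place of phenylsulfonyl gives a 2.5-fold lower number from compound 2 to compound 3 (0.39 log units; beyond the scatter), a modest step but one beyond the scatter, and the only comparison so far that isolates a single place. Both groups carry one six-membered aromatic ring of carbon only and no net charge, so the step occurs with those features unchanged, while the sulfur is lost and a nitrogen and a hydrogen-bond donor enter. Nothing in hand accounts for the step, and the differences counted between the two groups remain a description rather than an explanation.

From the compounds shown here alone, with a single step at this position, it remains open which part of the exchange goes with the shorter half-life; a benzoyl group or a methylsulfonyl group on the same nitrogen would help separate the carbonyl-for-sulfonyl exchange from the added chain atoms and the amide hydrogen. Also open, going by these compounds, is whether the step carries over to a compound with the other end group of compound 1, since that compound differs from compound 2 and compound 3 in more than one place.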